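A smaller group on the aromatic nitrogen

The compounds below may be only part of what the source reports. "The series", "measured", "known", "first", "only" and "open" are said of these compounds alone.

Of the compounds shown here, three sharing one core have been tested in an in vitro ADME assay on microsomes (Mus musculus) for metabolic stability (a higher number here means that the compound lasts longer, a lower number that the compound disappears faster), and only one of them gives a true number. Among the compounds with values here, compound 3 `CNC(=O)Nc1ccc(-c2nc(N3CC4CCC(C3)O4)c3cnn([C@H]4CC[C@@H](OC)CC4)c3n2)cc1` reads 0.283 h as its half-life, the single number available. Compound 1 `CNC(=O)Nc1ccc(-c2nc(N3CC4CCC(C3)O4)c3cnn(C(C)C)c3n2)cc1` reads > 0.5 h and this is a limit, not a number. Compound 2 `CNC(=O)Nc1ccc(-c2nc(N3CC4CCC(C3)O4)c3cnn(C)c3n2)cc1` reads > 0.5 h and this too is a limit. The comparison is therefore framed largely by the limit of > 0.5 h in this assay, at which 2 of the 3 values shown sit, and not by exact values.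

Compound 4 `CCn1ncc2c(N3CC4CCC(C3)O4)nc(-c3ccc(NC(=O)NC)cc3)nc21` has not been measured yet. It carries ethyl in place of 4-methoxycyclohexyl on an aromatic nitrogen, and the counted change is ethyl in place of 4-methoxycyclohexyl on an aromatic nitrogen in full.

Within the data shown here, two measured steps bear on this swap, namely an at least 1.7-fold lower number from compound 1 to compound 3 (0.24 log units; that floor lies within the scatter) and an at least 1.7-fold lower number from compound 2 to compound 3 (0.24 log units; that floor lies within the scatter) as the known floors. Compound 4 runs the same kind of swap backwards, and its ethyl, like the isopropyl of compound 1 and the methyl of compound 2, has no ring. The remaining step, a step that the two limits leave unreadable from compound 1 to compound 2, gives no size to work with.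

In this assay the expected step is a 2.1-fold higher number from compound 3 to compound 4 (0.33 log units; beyond the scatter) towards a longer half-life, and the result may well be only a limit. The estimate for compound 4 is 0.6 h with an expected range of 0.3 h to 1.5 h as the likely span.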

Compound 4, half-life: > 0.5 h
Compound 4: no number, only a limit; the forecaster's own chance of this, stated with the estimate: 60%; the middle value lies beyond the limit too.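

Compound 4 reads > 0.5 h in this assay, and this is a limit, not a number, so ethyl joins methyl and isopropyl as a third small group without a ring on this aromatic nitrogen that reaches the limit. Among the four compounds shown, only compound 3, with its 4-methoxycyclohexyl, gives a true number, and ethyl in place of that group gives an at least 1.7-fold higher number from compound 3 to compound 4 (0.24 log units; that floor lies within the scatter); this is only a floor, so the true step may be larger, but the floor alone does not establish a real difference. The steps among compound 1, compound 2 and compound 4 cannot be read, because none of these three has a true number: the limit of > 0.5 h in this assay, at which 3 of the 4 values shown sit.

On these data alone, how far apart the half-lives of the three compounds with small groups really lie remains open, so no order among methyl, ethyl and isopropyl can be given. Also open, as far as these compounds go, is whether the ring or its methoxy goes with the lower number of compound 3, and how a plain cyclohexyl or a longer chain such as butyl would read on this nitrogen.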